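Hydroxy for Bromo: Cytotoxicity Outlook for Compound 3

This account rests on a few compounds, and the source may have more. Where it says the series, first, only, none or still open, it means among the compounds named here.

Compound 2 `CN1CCN(c2nc(Oc3ccc(C#N)cn3)nc(-c3ccc(N4C(=O)CSC4c4ccc(Br)cc4)cc3)n2)CC1` has no reported result in an ADME assay on Vero cells (Chlorocebus sabaeus) for cytotoxicity, read by MTT assay, with a stated time of 72 h (a higher number here means a weaker inhibitor, a lower number a stronger inhibitor), where its entry reads "not determined" (no result reported). For the measured compounds named here, the only value in the set comes from compound 1 `CN1CCN(c2nc(Oc3ccc(C#N)cc3)nc(-c3ccc(N4C(=O)CSC4c4ccc(O)cc4)cc3)n2)CC1`. In this assay compound 1 gives > 62.5 ug/mL, which is a limit of the assay rather than a measured number. Compound 3 `CN1CCN(c2nc(Oc3ccc(C#N)cn3)nc(-c3ccc(N4C(=O)CSC4c4ccc(O)cc4)cc3)n2)CC1` is reached from compound 2 by a single change, (hydroxy in place of bromo on an aromatic carbon), with the hydroxy sitting para to a large group. Going by the values given here, no measured step between these two compounds exists, so neither the size nor the direction of the change can be read from the data. Compound 1 carries the same hydroxy group and sits at the limit, as shown by the limit of > 62.5 ug/mL in this assay, at which 1 of the 2 values shown sits. On that basis compound 3 is expected to be a weak inhibitor in this assay as well, most likely reported only as a limit. The estimate for compound 3 in this assay is 100 ug/mL, with an expected range from 40 ug/mL to 300 ug/mL.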

Compound 3, half-maximal inhibitory concentration: > 62.5 ug/mL
Compound 3 gave a limit, no number (the forecaster's own chance of this, stated with the estimate: 80%); the middle value does not contradict the limit.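

In this assay the results for compound 1 and compound 3 are both limits of the assay, so no step can be read between them, and none can be read from compound 2 to compound 3. The compounds shown leave open whether hydroxy in place of bromo, or 5-cyanopyridin-2-yl in place of 4-cyanophenyl, shifts cytotoxicity at all.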